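A Dimethoxyphenyl Ketone Analogue Awaiting Cytotoxicity Data

The source may report more compounds than this note shows. Statements on the series, on what has been measured and on what is new or still open speak of the compounds shown alone.

Compound 1, `COc1cc(-c2cc(/C=C/C(=O)c3ccc(Cl)c(Cl)c3)[nH]n2)cc(OC)c1OC`: 31%
Compound 2, `COc1ccc(-c2cc(/C=C/C(=O)c3ccc(N)cc3)[nH]n2)cc1OC`: -49%

In a functional assay on NCI-H460 cells (Homo sapiens) for cytotoxicity, read by sulforhodamine B assay, with a stated time of 48 h, tested at 10 uM (a higher number here means a weaker effect of the compound at the concentration tested, a lower number a stronger effect), compound 1 gives 31%, the highest of the two numbers. Compound 2 gives -49%, a far lower number, beyond the scatter. Compound 3, `COc1ccc(C(=O)/C=C/c2cc(-c3cc(OC)c(OC)c(OC)c3)n[nH]2)cc1OC`, differs from compound 1 in one place: 3,4-dimethoxyphenyl in place of 3,4-dichlorophenyl on a carbonyl carbon. Among the compounds with values here, no measured pair shows this particular change, so its size is uncertain. A step toward a lower number, possibly beyond the scatter, is expected, a number 16 percentage points lower from compound 1 to compound 3 (beyond the scatter). Compound 3 is estimated at 15%, with a range from -35% to 60%.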

Compound 3, a percentage reported as activity, at one concentration (the size of the read-out at that concentration, not a potency): -64%
For compound 3 the middle estimate is 79 percentage points above the measured one, and the stated range ends above it.
By their numbers in this assay, from the lowest: compound 3; then compound 2; then compound 1.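

With the rest of the structure unchanged, putting 3,4-dimethoxyphenyl in place of 3,4-dichlorophenyl on the carbonyl carbon gives, in this assay, a number 95 percentage points lower from compound 1 to compound 3 (beyond the scatter). Within the data shown here, this shows that the group at this position can by itself shift the read-out far beyond the scatter, which the earlier compounds, differing in more than one place, could not show. Nothing available explains the size of this step. Still open, as far as these compounds go, is whether a single methoxy group would suffice. Also open, from the compounds shown here alone, is how a phenyl carrying hydroxyl groups or a carboxylic acid would behave in this place.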